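The source may report more compounds than this note shows. Statements on the series, on what has been measured and on what is new or still open speak of the compounds shown alone.

Of the compounds shown here, three of one series have been measured in a functional assay for inhibition, read by Griess assay, with a stated time of 150 min, tested at 1 mM; on this read-out lower numbers stand for less inhibition and higher numbers for more inhibition at the one concentration tested (going by the name of the read-out). Compound 1, `COc1ccc2[nH]cc(C(=O)/C(C#N)=C/C=C(\Cl)c3ccc(OC)c(OC)c3)c2c1`, gives 74.2%. Compound 2, `COc1ccc2[nH]cc(C(=O)/C(C#N)=C/C=C(\Cl)c3ccc(Br)cc3)c2c1`, gives 76.7%, and compound 3, `COc1ccc(/C(Cl)=C/C=C(\C#N)C(=O)c2c[nH]c3ccccc23)cc1`, gives 76.9%. Going by the values given here, compound 1 thus holds the lowest of the three numbers, yet both others sit within the scatter of it: the one measured step, a number 2.5 percentage points higher from compound 1 to compound 2 (within the scatter), is within the scatter, and the gap between compound 1 and compound 3 is of the same size.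

Compound 4, `COc1ccc(/C(Cl)=C/C=C(\C#N)C(=O)c2c[nH]c3ccc(Br)cc23)cc1OC`, is not yet measured. Among the compounds with values here, it differs from compound 1 as follows. bromo in place of methoxy on an aromatic carbon The only measured step exchanges a group on a double-bonded chain carbon, not on the fused system of two rings, so no measured step bears directly on this change; what the three numbers show is that the read-out has stayed within the scatter across every change made so far. The expected step from compound 1 to compound 4 in this assay is therefore none beyond the scatter, a number 0.8 percentage points higher from compound 1 to compound 4 (within the scatter). For compound 4 the estimate in this assay is 75%, with a range from 60% to 88%.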

Compound 4, a percentage reported as inhibition, at one concentration (the size of the read-out at that concentration, not a potency): 57.5%
Compound 4: middle estimate off by 17.5 percentage points, on the high side, and the stated range ends above it.
By their numbers in this assay, from the lowest: compound 4; then compounds 1, 2 and 3 (each within the scatter of the next).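

In this assay the exchange of bromo for methoxy on an aromatic carbon of the fused system of two rings gives a number 16.7 percentage points lower from compound 1 to compound 4 (beyond the scatter) and is the only step shown that lies beyond the scatter. This position therefore matters to the read-out at the one concentration tested, whereas the exchange on the double-bonded chain carbon gave a number 2.5 percentage points higher from compound 1 to compound 2 (within the scatter) and did not separate its two compounds. Nothing available explains why this exchange lowers the number.

Only methoxy and bromo are compared directly at this carbon, so one step cannot show whether the lower number follows from the loss of methoxy or the arrival of bromo. On these data alone, how an amine, a hydroxyl or a longer alkoxy chain such as ethoxy would read out at this carbon remains open.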